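Phenyl in place of 2-phenylethenyl on compound 3

This account rests on a few compounds, and the source may have more. Where it says the series, first, only, none or still open, it means among the compounds named here.

Among the measured compounds shown here, all values below come from a functional assay on ECa-109 cells (Homo sapiens) for cytotoxicity, read by MTT assay, with a stated time of 72 h (a lower number here means a stronger inhibitor, a higher number a weaker inhibitor), and are the numbers available so far.

- Compound 1 `O=C1C(=Cc2ccc(Cl)cc2)C(=O)N(c2ccc(Cl)cc2)N1c1ccc(Cl)cc1` gives 17300 nM
- Compound 2 `O=C1C(=Cc2ccc(F)cc2F)C(=O)N(c2ccc(Cl)cc2)N1c1ccc(Cl)cc1` gives 13100 nM
- Compound 3 `O=C1C(=C/C=C/c2ccccc2)C(=O)N(c2ccc(Cl)cc2)N1c1ccc(Cl)cc1` gives 9900 nM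

Compound 3 stands level with the other two compounds, as its two steps show (a 1.7-fold lower number from compound 1 to compound 3 (0.24 log units; within the scatter)) and (a 1.3-fold lower number from compound 2 to compound 3 (0.12 log units; within the scatter)). Compound 4 `O=C1C(=Cc2ccccc2)C(=O)N(c2ccc(Cl)cc2)N1c1ccc(Cl)cc1` differs from compound 3 at one place (phenyl in place of 2-phenylethenyl on a double-bonded chain carbon bound to a double-bonded ring carbon).

All three measured steps are changes at this same place, and the third (a 1.3-fold lower number from compound 1 to compound 2 (0.12 log units; within the scatter)) is just as small. None of them leaves the scatter, so no step beyond the scatter is expected for compound 4 in this assay, though the data cannot rule one out. The expected step is a 1.3-fold higher number from compound 3 to compound 4 (0.12 log units; within the scatter) by this estimate, which points weakly toward the numbers of compound 1 and compound 2. Compound 4 is expected at 13000 nM (estimated range 7000 nM to 24000 nM).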

Compound 4, half-maximal inhibitory concentration: 32700 nM
Estimate against measurement, compound 4: 2.5-fold (0.40 log units) below; the measured number lies above the stated range.
By their numbers in this assay, from the lowest: compounds 3, 2, 1 and 4 (each within the scatter of the next, the first and the last beyond it).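

In this assay, this position now gives a change that leaves the scatter: phenyl in place of 2-phenylethenyl gives (a 3.3-fold higher number from compound 3 to compound 4 (0.52 log units; beyond the scatter)), and phenyl in place of 2,4-difluorophenyl gives (a 2.5-fold higher number from compound 2 to compound 4 (0.40 log units; beyond the scatter)). Hydrogen in place of chloro on an aromatic carbon stays within the scatter (a 1.9-fold higher number from compound 1 to compound 4 (0.28 log units; within the scatter)), so phenyl stands clearly apart only from the groups of compound 2 and compound 3, and compound 1 goes against any rule that every larger group here lowers the number. Nothing measured here explains these steps.

Still open, as far as these compounds go, is whether an amine, a carboxylic acid or a chain longer than 2-phenylethenyl at this position would lower the number further. From the compounds shown here alone, it is also open whether these differences would hold in another cell line.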